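Removing the aryl methyl group from compound 3

The source may report more compounds than this note shows. Statements on the series, on what has been measured and on what is new or still open speak of the compounds shown alone.

Values so far in a functional assay on MCF7 cells (Homo sapiens) for inhibition, read by MTT assay, with a stated time of 72 h (a higher number here means a weaker inhibitor, a lower number a stronger inhibitor), for the series:
compound 1 `COc1cc2c(Oc3ccc(NC(=O)c4nn(-c5ccc(C)cc5)cc(C)c4=O)cc3)ccnc2cc1OCCCCCCC(=O)NO` gives 2560 nM
compound 2 `COc1cc2c(Oc3ccc(NC(=O)c4nn(-c5cccc(C)c5)cc(C)c4=O)cc3)ccnc2cc1OCCCCCCC(=O)NO` gives 1680 nM
compound 3 `COc1cc2c(Oc3ccc(NC(=O)c4nn(-c5ccccc5C)cc(C)c4=O)cc3)ccnc2cc1OCCCCCCC(=O)NO` gives 1830 nM

Compound 3 at 1830 nM is not separated from the other two compounds in this assay and lies closest to compound 2. The step of a 1.1-fold higher number from compound 2 to compound 3 (0.04 log units; within the scatter) is its smallest and the step of a 1.4-fold lower number from compound 1 to compound 3 (0.15 log units; within the scatter) its largest, and both lie within the scatter. The remaining step of a 1.5-fold lower number from compound 1 to compound 2 (0.18 log units; within the scatter) also lies within the scatter.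

Compared with compound 3, compound 4 `COc1cc2c(Oc3ccc(NC(=O)c4nn(-c5ccccc5)cc(C)c4=O)cc3)ccnc2cc1OCCCCCCC(=O)NO` carries one change (hydrogen in place of methyl on an aromatic carbon) with hydrogen in place of methyl on an aromatic carbon, so that 2-methylphenyl becomes phenyl. Within the data shown here, no measured pair removes the methyl outright, and the size of that change is therefore unmeasured. The closest evidence is the three steps above, which only relocate the methyl on the phenyl ring. None of them exceeds the scatter, so no step beyond the scatter is expected in this assay and no direction is favoured. The estimated step is a 1.0-fold higher number from compound 3 to compound 4 (0.02 log units; within the scatter) and is expected to stay within the scatter. Compound 4 is expected at 1900 nM with an estimated range from 1100 nM to 3200 nM in this measurement.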

Compound 4, half-maximal inhibitory concentration: 1610 nM
For compound 4 the middle estimate is 1.2-fold (0.07 log units) above the measured one, within the range that was stated.
By their numbers in this assay, from the lowest: compounds 4, 2, 3 and 1 (each within the scatter of the next).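

In this assay, hydrogen in place of methyl on an aromatic carbon gives a 1.1-fold lower number from compound 3 to compound 4 (0.06 log units; within the scatter) and a 1.0-fold lower number from compound 2 to compound 4 (0.02 log units; within the scatter) and a 1.6-fold lower number from compound 1 to compound 4 (0.20 log units; within the scatter), so all three comparisons with the phenyl compound stay within the scatter. The earlier compounds only relocated the methyl around the phenyl ring on the aromatic nitrogen; compound 4 adds the case without it and shows that, among these four compounds, neither the presence of the methyl nor its location separates the values in this assay. No accompanying measurement speaks to why these values sit so close together.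

The compounds shown leave open whether a group other than methyl on this phenyl ring, such as methoxy, an amine or a carboxylic acid, would produce a step beyond the scatter, and whether a longer alkyl chain in place of the whole phenyl ring would do so. All four compounds share the rest of the core, so these readings speak only for the aryl group on the aromatic nitrogen and not for any other part of the structure.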